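This account rests on a few compounds, and the source may have more. Where it says the series, first, only, none or still open, it means among the compounds named here.

Values in a functional assay on HeLa cells (Homo sapiens) for inhibition; on this read-out higher numbers stand for weaker inhibition and lower numbers for stronger inhibition:
- compound 1 `COc1cc(/C=C/c2ccc3[nH]ccc3c2)cc(OC)c1OC`: 250 nM
- compound 2 `COc1cc(/C=C\c2ccc3[nH]ccc3c2)cc(OC)c1OC`: 34 nM

Of the two measured compounds, compound 2 has the lower number and so the stronger inhibition in this assay, at 34 nM. Going by the values given here, the only measured step is a 7.4-fold lower number from compound 1 to compound 2 (0.87 log units; beyond the scatter), and it comes with a change of double-bond configuration alone (the fact that compounds 1 and 2 differ only in the configuration as drawn).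

The next compound is compound 3 `COc1cc(/C=C\c2ccc3c(ccn3C)c2)cc(OC)c1OC`, which keeps the double bond as drawn in compound 2. The change is methyl in place of hydrogen on an aromatic nitrogen. Among the compounds with values here, the measured step bears on it only weakly, since no measured pair differs at this nitrogen, so its size gives no direct guide and the range stays wide. The expected change is small, with none beyond the scatter: a 1.2-fold higher number from compound 2 to compound 3 (0.07 log units; within the scatter). For compound 3 the estimate is 40 nM, with an expected range of 10 nM to 200 nM.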

Compound 3, half-maximal inhibitory concentration: 250 nM
Compound 3: the middle estimate sits 6.3-fold (0.80 log units) below what was measured; measured number outside the range, above it.
By their numbers in this assay, from the lowest: compound 2; then compounds 1 and 3 (each within the scatter of the next).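

In this assay, going by these compounds alone, the aromatic nitrogen proves sensitive to substitution: a 7.4-fold higher number from compound 2 to compound 3 (0.87 log units; beyond the scatter) comes with methyl in place of hydrogen, the first measured change at this place. With the double bond drawn Z, even this group of one carbon on the nitrogen therefore weakens inhibition beyond the scatter. No measured fact on record speaks to the reason for this step.

Open, going by these compounds, is whether ethyl, a longer chain or a chain ending in a carboxylic acid on this nitrogen would move the number in the same direction as methyl, or whether an acetyl group would differ from them. Also open, on these data alone, is whether methyl on this nitrogen would give a step of similar size with the double bond drawn E, as in compound 1.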